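The compounds below may be only part of what the source reports. "The series", "measured", "known", "first", "only" and "open" are said of these compounds alone.

Measured compounds:
compound 1 `CC(C)[C@H]1CC[C@@]2(CO2)[C@H]2C(=O)OCC(C(=O)OCc3ccc(-c4ccc([N+](=O)[O-])cc4)o3)=C[C@H]12` — 3600 nM
compound 2 `CC(C)[C@H]1CC[C@@]2(CO2)[C@H]2C(=O)OCC(C(=O)O)=C[C@H]12` — 509 nM
compound 3 `CC(C)[C@H]1CC[C@@](O)(CI)[C@H]2C(=O)OCC(C(=O)O)=C[C@H]12` — 10100 nM

In a functional assay on WM 266-4 cells (Homo sapiens) for inhibition, with a stated time of 72 h (on this read-out lower numbers stand for stronger inhibition and higher numbers for weaker inhibition), compound 2 gives 509 nM, the lowest number of the three; compound 1 stands above it by a margin beyond the scatter, and compound 3 stands further above still, also beyond the scatter. Compound 4 `COC(=O)C1=C[C@@H]2[C@@H](C(C)C)CC[C@@]3(CO3)[C@H]2C(=O)OC1` differs from compound 2 by methyl in place of hydrogen on an oxygen next to a carbonyl group, carboxy to methoxycarbonyl. For the measured compounds named here, no pair of measured compounds shows this same change, so the size of the step can only be guessed. Going by the values given here, the one measured compound without the free carboxy, compound 1, gives 3600 nM in this assay, a weaker number than compound 2, though its group on that oxygen is far larger than methyl. A modest rise in the number is therefore expected, and the step of a 2.4-fold higher number from compound 2 to compound 4 (0.37 log units; beyond the scatter) is estimated to be at or just beyond the scatter, in the direction of weaker inhibition. Compound 4 is expected at 1200 nM, with a range of 400 nM to 4000 nM.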

Compound 4, half-maximal inhibitory concentration: 4100 nM
Compound 4: middle estimate off by 3.4-fold (0.53 log units), on the low side, and the stated range ends below it.
By their numbers in this assay, from the lowest: compound 2; then compounds 1 and 4 (each within the scatter of the next); then compound 3.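

In this assay, the change from carboxy to methoxycarbonyl gives an 8.1-fold higher number from compound 2 to compound 4 (0.91 log units; beyond the scatter) on the shared core, so a single methyl on this oxygen is enough to move the number beyond the scatter, towards weaker inhibition. Compound 1, with a far larger group on the same oxygen, gives 3600 nM and compound 4 gives 4100 nM, values within the scatter of each other, so across these two esters the number does not follow the size of the group. Nothing available here accounts for the step.

Still open, as far as these compounds go, is whether a primary amide or an ethyl ester at this position would stay as far from compound 2 as these esters do. Also open, from the compounds shown here alone, is whether the same change on the core of compound 3 would give a step of similar size.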